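Acyl group changes on the piperidine-bearing hydantoin sulfonate series

A few compounds are considered here, and "the series" means these few. Any claim that something is new, unique, unknown or untested is made for them only; others in the source may bear on it.

Compound 1 `CC(C)(C)OC(=O)N1CCC(CCN2C(=O)NC(=O)C2Cc2ccc(OS(=O)(=O)c3cccc4cnccc34)cc2)CC1` — 1010 nM
Compound 2 `CC(C)(C)OC(=O)N1CCC(N2C(=O)NC(=O)C2Cc2ccc(OS(=O)(=O)c3cccc4cnccc34)cc2)CC1` — 355 nM
Compound 3 `CC(C)C(=O)N1CCC(N2C(=O)NC(=O)C2Cc2ccc(OS(=O)(=O)c3cccc4cnccc34)cc2)CC1` — 7220 nM

In an assay on HEK293 cells for antagonist activity at P2X purinoceptor 7 (Homo sapiens), read by fluorescence, with a stated time of 2 h (on this read-out higher numbers stand for weaker inhibition and lower numbers for stronger inhibition), compound 3 gives 7220 nM, the highest of the three numbers; compound 2 gives 355 nM and compound 1 gives 1010 nM. Going by the values given here, the one step that touches the same place is a 20-fold higher number from compound 2 to compound 3 (1.31 log units; beyond the scatter), a large move. Compound 4 `O=C1NC(=O)N(C2CCN(C(=O)CC3CC4CCC3C4)CC2)C1Cc1ccc(OS(=O)(=O)c2cccc3cnccc23)cc1` differs from compound 3 by a group of 8 heavy atoms (8 carbon; 2 five-membered non-aromatic rings of carbon only) in place of a group of 3 heavy atoms (3 carbon; no ring), on a carbonyl carbon. Among the compounds with values here, no measured step covers this exact change, so the expectation rests loosely on compound 2, whose tert-butoxy carbonyl gave 355 nM against the isopropyl of compound 3 at 7220 nM; a larger group on this carbonyl may move the number down, but the size is uncertain. Compound 4 is therefore estimated at 2000 nM, between 400 nM and 10000 nM, an expected step of a 3.6-fold lower number from compound 3 to compound 4 (0.56 log units; beyond the scatter).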

Compound 4, half-maximal inhibitory concentration: 109 nM
Compound 4: the middle estimate sits 18-fold (1.26 log units) above what was measured; the measured number lies below the stated range.
By their numbers in this assay, from the lowest: compound 4; then compound 2; then compound 1; then compound 3.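

In this assay, the group on this carbonyl carbon need not stay small: the carbon-only group with 2 five-membered rings gives a 66-fold lower number from compound 3 to compound 4 (1.82 log units; beyond the scatter). It also improves on tert-butoxy, with a 3.3-fold lower number from compound 2 to compound 4 (0.51 log units; beyond the scatter), so an oxygen in this group is not required for a low number. No measurement shown here explains this gain. The compounds shown leave open whether the rings matter or only the number of carbons, which a straight hexyl chain on the same carbonyl carbon would help to separate.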